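The source may report more compounds than this note shows. Statements on the series, on what has been measured and on what is new or still open speak of the compounds shown alone.

Three compounds have been measured in an ADME assay on RAW264.7 cells (Mus musculus) for cytotoxicity, read by MTT assay, with a stated time of 48 h; a higher number here means a weaker inhibitor, a lower number a stronger inhibitor:

Compound 1 `N#Cc1ccc(-c2ccc(CNCCNc3ccnc4cc(Cl)ccc34)s2)cc1` gives 26100 nM.
Compound 2 `N#Cc1ccc(-c2ccc(CNCCCNc3ccnc4cc(Cl)ccc34)s2)cc1` gives 3550 nM.
Compound 3 `Clc1ccc2c(NCCNCc3ccc(-c4cccnc4)s3)ccnc2c1` gives 16400 nM.

Compound 2 gives the lowest of the three numbers, and its gap to compound 3, as to compound 1, lies beyond the usual scatter. Compound 1 and compound 2 share most of their structure, but the difference between their two cores is not broken down here. From compound 1 to compound 3 the change is pyridin-3-yl in place of 4-cyanophenyl on an aromatic carbon, and it made a 1.6-fold lower number from compound 1 to compound 3 (0.20 log units; within the scatter).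

Compound 4 `Clc1ccc2c(NCCCNCc3ccc(-c4cccnc4)s3)ccnc2c1` has not yet been measured. It differs from compound 2 by pyridin-3-yl in place of 4-cyanophenyl on an aromatic carbon, the same change that separates compound 3 from compound 1, at the same place. Because that change gave a 1.6-fold lower number from compound 1 to compound 3 (0.20 log units; within the scatter), the step is expected to be of like size, a 1.5-fold lower number from compound 2 to compound 4 (0.19 log units; within the scatter). Resting on the value of compound 2, 3550 nM, compound 4 is therefore estimated at 2300 nM in this assay, with a likely range from 1000 nM to 5500 nM.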

Compound 4, half-maximal inhibitory concentration: 21600 nM
Beside the measured number, compound 4's estimate is 9.4-fold (0.97 log units) below it; the whole stated range lies below it.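

On the core of compound 2, putting pyridin-3-yl in place of 4-cyanophenyl on an aromatic carbon gave a 6.1-fold higher number from compound 2 to compound 4 (0.78 log units; beyond the scatter) in this assay, whereas the same change produced no step beyond the scatter on the core of compound 1. The two steps therefore do not agree: the same change on two cores in this assay, a 1.6-fold lower number (0.20 log units; within the scatter) from compound 1 to compound 3 and a 6.1-fold higher number (0.78 log units; beyond the scatter) from compound 2 to compound 4, 9.7-fold (0.99 log units) apart, beyond the scatter of two such steps. This shows that, for these two pairs, the step read on one core was no safe guide to the step on the other, but it does not show what in the two cores sets the steps apart, and two pairs give no rule for any further core.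

The compounds shown leave open how this change would behave on a core with a longer chain, which would show whether the step on the core of compound 2 is an isolated case. They also leave open whether a plain phenyl or a pyridin-4-yl group in the same place would follow compound 3 or compound 4 on their respective cores.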